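Aziridine substituent series: removing the nonyl chain

The compounds below may be only part of what the source reports. "The series", "measured", "known", "first", "only" and "open" are said of these compounds alone.

Compound 2 `CCCCCCCCCC1(CO[C@@H]2O[C@@H]3CO[C@H](c4ccccc4)O[C@@H]3[C@H](OCc3ccccc3)[C@H]2OCc2ccccc2)CN1S(=O)(=O)c1ccc(C)cc1` gives the lowest number of the two measured: in a functional assay on A549 cells (Homo sapiens) for cytotoxicity, read by MTT assay, with a stated time of 48 h (on this read-out lower numbers stand for stronger inhibition and higher numbers for weaker inhibition), compound 2 gives 154000 nM. Compound 1 `Cc1ccc(S(=O)(=O)N2CC2(CO[C@@H]2O[C@@H]3CO[C@H](c4ccccc4)O[C@@H]3[C@H](OCc3ccccc3)[C@H]2OCc2ccccc2)c2ccccc2)cc1` sits higher; in this assay compound 1 gives 599000 nM. Within the data shown here, the only measured step, a 3.9-fold lower number from compound 1 to compound 2 (0.59 log units; beyond the scatter), is the one that bears on the next change. Compound 3 `Cc1ccc(S(=O)(=O)N2CC2CO[C@@H]2O[C@@H]3CO[C@H](c4ccccc4)O[C@@H]3[C@H](OCc3ccccc3)[C@H]2OCc2ccccc2)cc1` carries hydrogen in place of nonyl on a saturated ring carbon. With the chain taken away entirely, the step is expected to run the other way from that single comparison, and a modest rise in the number is estimated, a 3.2-fold higher number from compound 2 to compound 3 (0.51 log units; beyond the scatter). Compound 3 is therefore expected at 500000 nM, within 150000 nM to 1800000 nM.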

Compound 3, half-maximal inhibitory concentration: 73000 nM
Estimate against measurement, compound 3: 6.8-fold (0.84 log units) above; the whole stated range lies above it.
By their numbers in this assay, from the lowest: compound 3; then compound 2; then compound 1.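

In this assay hydrogen in place of nonyl on the saturated ring carbon gives a 2.1-fold lower number from compound 2 to compound 3 (0.32 log units; beyond the scatter) and hydrogen in place of phenyl gives an 8.2-fold lower number from compound 1 to compound 3 (0.91 log units; beyond the scatter) so compound 3 has the lowest number of the three. Nonyl improves on phenyl but not on hydrogen, so neither substituent is needed at this position for the lowest number seen here. Nothing available accounts for this order.

Open, as far as these compounds go, is whether a shorter chain such as ethyl at this ring carbon would fall between compound 3 and compound 2. Also open, from the compounds shown here alone, is how an amine or a carboxylic acid there would compare with hydrogen.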